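The compounds below may be only part of what the source reports. "The series", "measured", "known", "first", "only" and "open" are said of these compounds alone.

Three compounds share one core and differ only in the group on a nitrogen on the aromatic ring. Compound 1 `CCCCCCCCCCCCNc1nc(SCc2ccc(C(F)(F)F)cc2)nc2ccccc12` carries a long saturated chain there; in a functional assay on PC-3 cells (Homo sapiens) for cytotoxicity, read by MTT assay, with a stated time of 72 h (a higher number here means a weaker inhibitor, a lower number a stronger inhibitor), compound 1 gives 26000 nM. Compound 2 `CCCCCCCCCCCCCCNc1nc(SCc2ccc(C(F)(F)F)cc2)nc2ccccc12` carries a longer chain, and in this assay compound 2 reaches only the assay's limit, > 50000 nM, with no number. That reading is the limit of > 50000 nM in this assay, at which 1 of the 3 values shown sits. Compound 3 `FC(F)(F)c1ccc(CSc2nc(Nc3cccc(Cl)c3)c3ccccc3n2)cc1` carries 3-chlorophenyl instead; in this assay compound 3 gives 13400 nM, the lower of the two numbers measured, although the gap to compound 1 lies within the scatter. Compound 4 `CCOc1ccc(Nc2nc(SCc3ccc(C(F)(F)F)cc3)nc3ccccc23)cc1` differs from compound 3 in one place: 4-ethoxyphenyl in place of 3-chlorophenyl on a nitrogen on an aromatic ring. Among the compounds with values here, the only measured step, an at least 1.9-fold higher number from compound 1 to compound 2 (0.28 log units; that floor lies within the scatter), concerns lengthening a saturated chain and does not touch an aryl group, so no measured step bears on this change. No shift beyond the scatter is therefore expected, a 1.1-fold higher number from compound 3 to compound 4 (0.05 log units; within the scatter). Compound 4 is estimated at 15000 nM, between 5000 nM and 45000 nM.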

Compound 4, half-maximal inhibitory concentration: 32100 nM
Compound 4: middle estimate off by 2.1-fold (0.33 log units), on the low side; measured number inside the range.
By their numbers in this assay, from the lowest: compounds 3, 1 and 4 (each within the scatter of the next, the first and the last beyond it). At a limit, above all of these: compound 2.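

In this assay, the swap of 3-chlorophenyl for 4-ethoxyphenyl on this nitrogen gives a 2.4-fold higher number from compound 3 to compound 4 (0.38 log units; beyond the scatter), a modest step but the first measured one between two aryl groups at this position. It shows that the number can respond to which aryl group sits on this nitrogen, and here the change goes toward a weaker inhibitor. Within the data shown here, nothing measured so far bears on why this step occurs.

The step replaces one whole aryl group with another, so it cannot separate the loss of the chlorine from the gain of the ethoxy group, or either of these from where each sits on the ring. Plain phenyl, 4-chlorophenyl and 3-ethoxyphenyl on the same nitrogen would each change less at once, and the compounds shown leave their numbers open.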